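Bringing back the methylamino group on a saturated chain

The source may report more compounds than this note shows. Statements on the series, on what has been measured and on what is new or still open speak of the compounds shown alone.

In a functional assay on HCT-116 cells (Homo sapiens) for inhibition, read by MTT assay, with a stated time of 72 h (a lower number here means a stronger inhibitor of growth, a higher number a weaker inhibitor of growth), compound 2 (`O=C(O)/C=C/c1ccncc1-c1ccc2ccccc2c1`) gives > 30000 nM, which is a limit of the assay and not a number. Compound 2 therefore has no exact place on the scale. Compound 3 (`CNC(=O)CCc1ccncc1-c1ccc2ccccc2c1`) differs from it as follows: 2-(methylcarbamoyl)ethyl in place of 2-carboxyethenyl on an aromatic carbon. Here 2-(methylcarbamoyl)ethyl stands in place of 2-carboxyethenyl on an aromatic carbon. Among the compounds with values here, one measured step bears on this change. Compound 1 (`CNC(=O)/C=C/c1ccncc1-c1ccc2ccccc2c1`), which carries methylamino on its carbonyl carbon, gives 6550 nM. Putting hydroxy in place of that methylamino gave an at least 4.5-fold higher number from compound 1 to compound 2 (0.66 log units; beyond the scatter). Compound 3 has methylamino back on its carbonyl carbon, so a step of similar size towards a lower number is expected in this assay. Within the data shown here, no measured step shows what the loss of the chain's double bond does. The expected step is an at least 3.7-fold lower number from compound 2 to compound 3 (0.57 log units; beyond the scatter). For compound 3 the estimated value is 8000 nM, with an expected range of 3000 nM to 22000 nM.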

Compound 3, concentration for 50% growth inhibition: 19300 nM
Estimate against measurement, compound 3: 2.4-fold (0.38 log units) below; measured number inside the range.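

With methylamino kept on the carbonyl carbon, losing the chain's double bond gives a 2.9-fold higher number from compound 1 to compound 3 (0.47 log units; beyond the scatter) in this assay, so this position shows a modest response to saturating the chain, which the earlier pair could not reveal. Placing 2-(methylcarbamoyl)ethyl where 2-carboxyethenyl stood gives an at least 1.5-fold lower number from compound 2 to compound 3 (0.19 log units; that floor lies within the scatter), and this shows only that compound 3 need not sit beyond the top of the scale. That floor is all that can be read, because compound 2 stands at a limit of the assay and not at a number: the limit of > 30000 nM in this assay, at which 1 of the 3 values shown sits.

As far as these compounds go, it remains open how a carboxylic acid on the saturated chain would compare with compound 3. Also open, from the compounds shown here alone, is whether a longer chain or a simple amine at this position would give a lower number than either amide.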